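Aryl replacement on the shared core: notes toward compound 3

The compounds below may be only part of what the source reports. "The series", "measured", "known", "first", "only" and "open" are said of these compounds alone.

The series keeps the core of compound 1 `CCOC(=O)C1=Cc2ccccc2OC1(OCc1cc(-c2ccc([N+](=O)[O-])cc2)no1)C(F)(F)F` and varies the aryl group on the five-membered aromatic ring with 1 nitrogen and 1 oxygen. In a functional assay on MCF7 cells (Homo sapiens) for inhibition, read by MTT assay, with a stated time of 24 h (a lower number here means a stronger inhibitor, a higher number a weaker inhibitor), compound 1 gives only a limit of the assay, > 150000 nM. Compound 2 `CCOC(=O)C1=Cc2ccccc2OC1(OCc1cc(-c2ccc(C)cc2)no1)C(F)(F)F` carries methyl in place of nitro on an aromatic carbon. In this assay compound 2 likewise gives only a limit, > 150000 nM. The step that the two limits leave unreadable from compound 1 to compound 2 cannot be sized because both values sit at the limit of > 150000 nM in this assay, at which 2 of the 2 values shown sit.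

Compound 3 `CCOC(=O)C1=Cc2ccccc2OC1(OCc1cc(-c2cccc(C(F)(F)F)c2)no1)C(F)(F)F` differs from compound 2 by 3-(trifluoromethyl)phenyl in place of 4-methylphenyl on an aromatic carbon. Going by the values given here, no measured step gives a readable size, so nothing can be carried over to this change; the two values known so far are both limits. Compound 3 is expected to stay at the limit as well, the expected step that the limit leaves unreadable from compound 2 to compound 3 meaning no change beyond the scatter. The estimate for compound 3 in this assay is 200000 nM, expected between 80000 nM and 600000 nM.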

Compound 3, half-maximal inhibitory concentration: 22100 nM
For compound 3 the middle estimate is 9.0-fold (0.96 log units) above the measured one, outside the stated range (below it).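

In this assay, the aryl group on the five-membered aromatic ring with 1 nitrogen and 1 oxygen proves able to move the read-out off the limit: 3-(trifluoromethyl)phenyl in place of 4-methylphenyl gives an at least 6.7-fold lower number from compound 2 to compound 3 (0.83 log units; beyond the scatter), and in place of 4-nitrophenyl it gives an at least 6.7-fold lower number from compound 1 to compound 3 (0.83 log units; beyond the scatter). Going by these compounds alone, compound 3 is the only one of the three with a value that is a number and not a limit, so these are the first readable steps at this position. Each step is readable only as a minimum, and its full size stays unknown: the limit of > 150000 nM in this assay, at which 2 of the 3 values shown sit.

Whether the trifluoromethyl group alone accounts for these steps remains open, as compound 3 is the only compound shown that carries it on the aryl group. From the compounds shown here alone, how an aryl group bearing an amine or a carboxylic acid would read in this assay is also open.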